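One inverted stereocentre: compound 2 to compound 4

A few compounds are considered here, and "the series" means these few. Any claim that something is new, unique, unknown or untested is made for them only; others in the source may bear on it.

In a toxicity assay on L02 cells (Homo sapiens) for cytotoxicity, read by MTT assay, with a stated time of 72 h (on this read-out lower numbers stand for stronger inhibition and higher numbers for weaker inhibition), compound 1 (`CN(C)CCCCCn1c2c(c3ccccc31)C(=O)c1c[n+]([O-])c3ccccc3c1C2=O`) gives 240 nM and compound 3 (`CN1CCN(CCCn2c3c(c4ccccc42)C(=O)c2c[n+]([O-])c4ccccc4c2C3=O)CC1`) gives 230 nM. Compound 2 (`O=C1c2c[n+]([O-])c3ccccc3c2C(=O)c2c1c1ccccc1n2Cc1cn([C@@H]2C[C@H](O)[C@@H](CO)O2)nn1`) gives 630 nM, the highest of the three numbers, and its gap to each of the other two lies beyond the scatter.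

Compound 4 (`O=C1c2c[n+]([O-])c3ccccc3c2C(=O)c2c1c1ccccc1n2Cc1cn([C@H]2C[C@H](O)[C@@H](CO)O2)nn1`) has the same atoms and bonds as compound 2. The change is the two compounds have the same atoms and bonds and differ only in configuration as drawn: 1 of 3 stereo elements differ; a stereocentre at a saturated ring carbon is drawn S in compound 2 and R in compound 4: the two compounds differ only in configuration as drawn, with a stereocentre at a saturated ring carbon drawn S in compound 2 and R in compound 4.

For the measured compounds named here, the only measured step between two compounds that differ in one place is a 1.0-fold lower number from compound 1 to compound 3 (0.02 log units; within the scatter). It places 4-methylpiperazin-1-yl in place of 2-(dimethylamino)ethyl on a chain and involves no change of configuration, so it bears on this change only weakly. Going by the values given here, no pair differing only in configuration has been measured, and no direction can be favoured from these data. The expectation in this assay is therefore no step beyond the scatter, anchored on compound 2 at 630 nM, with a wide margin on both sides. The estimated change is a 1.1-fold lower number from compound 2 to compound 4 (0.02 log units; within the scatter). Compound 4 is estimated at 600 nM, with an expected range from 250 nM to 1500 nM.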

Compound 4, half-maximal inhibitory concentration: 280 nM
Beside the measured number, compound 4's estimate is 2.1-fold (0.33 log units) above it, and the stated range covers the measured number.
By their numbers in this assay, from the lowest: compounds 3, 1 and 4 (each within the scatter of the next); then compound 2.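

In this assay, a 2.3-fold lower number from compound 2 to compound 4 (0.35 log units; beyond the scatter) shows that configuration at this saturated ring carbon alone can move the number by a modest step beyond the scatter, with the form drawn R giving the lower number. The earlier step, a 1.0-fold lower number from compound 1 to compound 3 (0.02 log units; within the scatter), lies within the scatter, concerns a change on a chain and involves no change of configuration, so it gave no reading on stereochemistry at this position. The step can be assigned to this single stereocentre because no other structural change accompanies it: the fact that compounds 2 and 4 differ only in the configuration as drawn.

The compounds shown leave open whether the other two stereo elements of this saturated ring carry a comparable step, since only one of the three differs between these two compounds. They also leave open whether this inversion would give a step of the same direction and size with an amine or a methoxy group in place of the ring hydroxyl, or with a longer chain in place of the single carbon that links the saturated-ring unit to the shared core.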